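Chloro in Place of Methoxy: Compound 2 to Compound 4

This account rests on a few compounds, and the source may have more. Where it says the series, first, only, none or still open, it means among the compounds named here.

Compound 2 `COc1ccccc1C(=O)NC(=S)NNc1ncnc2ccccc12` sits at the weak end of what has been measured: in a functional assay on KB cells (Homo sapiens) for cytotoxicity, read by MTT assay, with a stated time of 72 h (on this read-out higher numbers stand for weaker inhibition and lower numbers for stronger inhibition), compound 2 gives > 50000 nM, which is a limit of the assay rather than a number. Among the measured compounds shown here, of the two compounds with numbers, compound 1 `COc1cc2ncnc(NNC(=S)NC(=O)c3ccccc3F)c2cc1OC` gives 4070 nM and compound 3 `COc1cc2ncnc(NNC(=S)NC(=O)c3ccc(C(F)(F)F)cc3)c2cc1OC` gives 8840 nM; the only measured step, a 2.2-fold higher number from compound 1 to compound 3 (0.34 log units; beyond the scatter), exchanges one aryl group on the carbonyl carbon for another, on a core that compound 2 does not share. Compound 4 `O=C(NC(=S)NNc1ncnc2ccccc12)c1ccccc1Cl` differs from compound 2 by chloro in place of methoxy on an aromatic carbon. For the measured compounds named here, no measured step covers this exchange; the sole foothold is the limit of > 50000 nM in this assay, at which 1 of the 3 values shown sits. The step from compound 2 to compound 4 is therefore expected to be an at least 1.2-fold lower number from compound 2 to compound 4 (0.09 log units; that floor lies within the scatter). Compound 4 is estimated at 40000 nM, within 10000 nM to 150000 nM.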

Compound 4, half-maximal inhibitory concentration: 7710 nM
The estimate for compound 4 lay 5.2-fold (0.72 log units) above the measured number; measured number outside the range, below it.
By their numbers in this assay, from the lowest: compounds 1, 4 and 3 (each within the scatter of the next, the first and the last beyond it). At a limit, above all of these: compound 2.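

With the core held fixed, chloro in place of methoxy on this aromatic carbon gives an at least 6.4-fold lower number from compound 2 to compound 4 (0.81 log units; beyond the scatter) in this assay. This single exchange is enough to bring this core from a limit to a measured number, which the earlier step, made on another core, could not show. The value of compound 2 is a limit and not a number, so the size of the change remains a floor: the limit of > 50000 nM in this assay, at which 1 of the 4 values shown sits.

Left open is how a methyl group, an amine or a carboxylic acid on this aromatic carbon would read. Also open, on these data alone, is whether chloro in place of methoxy would have a similar effect on the core of compound 1.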